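A few compounds are considered here, and "the series" means these few. Any claim that something is new, unique, unknown or untested is made for them only; others in the source may bear on it.

Among the measured compounds shown here, compound 3 `CCS(=O)(=O)Nc1cccc2c1CCC2c1ncc[nH]1` sits second highest of the three numbers so far in a functional assay on CHO cells for agonist activity at Alpha-1A adrenergic receptor (Homo sapiens), read by FLIPR and calcium flux; a higher number here means that more compound is needed for the effect, a lower number that less compound is needed: compound 3 gives 32 nM, compound 1 `CS(=O)(=O)Nc1cccc2c1CCC2c1ncc[nH]1` gives 70 nM, and compound 2 `c1cc(-c2cn[nH]c2)c2c(c1)C(c1ncc[nH]1)CC2` gives 14 nM. The step of a 2.2-fold lower number from compound 1 to compound 3 (0.34 log units; beyond the scatter) and the step of a 2.3-fold higher number from compound 2 to compound 3 (0.36 log units; beyond the scatter) place compound 3 between the other two, with both gaps beyond the scatter.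

Compound 4 `Cc1oncc1-c1cccc2c1CCC2c1ncc[nH]1` is reached from compound 3 by one change: 5-methyl-1,2-oxazol-4-yl in place of (ethylsulfonyl)amino on an aromatic carbon. The measured steps that bear on it are those in which a sulfonamide on the aromatic carbon is exchanged for a five-membered aromatic ring, or the reverse. The step of a 5.0-fold lower number from compound 1 to compound 2 (0.70 log units; beyond the scatter) and the step of a 2.3-fold higher number from compound 2 to compound 3 (0.36 log units; beyond the scatter) both show that the aromatic ring at this position goes with a lower number in this assay than the sulfonamide. A similar, modest move toward a lower number is therefore expected for compound 4, though the 5-methyl-1,2-oxazol-4-yl ring is not the same ring as in compound 2 and carries no hydrogen-bond donor, so the size is uncertain. Compound 4 is expected to give 18 nM in this assay, with a range of 7 nM to 50 nM, which would be a step of a 1.8-fold lower number from compound 3 to compound 4 (0.25 log units; within the scatter).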

Compound 4, half-maximal effective concentration: 111 nM
Compound 4: the middle estimate sits 6.2-fold (0.79 log units) below what was measured; the whole stated range lies below it.
By their numbers in this assay, from the lowest: compound 2; then compound 3; then compounds 1 and 4 (each within the scatter of the next).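

Compound 4 shows that a five-membered aromatic ring on this aromatic carbon does not by itself go with a lower number in this assay: exchanging the (ethylsulfonyl)amino group for 5-methyl-1,2-oxazol-4-yl gives the opposite direction (a 3.5-fold higher number from compound 3 to compound 4 (0.54 log units; beyond the scatter)). The identity of the ring matters, as the exchange of 1H-pyrazol-4-yl for 5-methyl-1,2-oxazol-4-yl gives the largest step in the set (a 7.9-fold higher number from compound 2 to compound 4 (0.90 log units; beyond the scatter)), while the exchange for methanesulfonamido stays within the scatter (a 1.6-fold higher number from compound 1 to compound 4 (0.20 log units; within the scatter)). No measurement at hand explains this difference between the two rings.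

The compounds shown leave open whether the 5-methyl group or the 1,2-oxazole ring itself accounts for the step. They also leave open how a 1,2-oxazol-4-yl ring without the methyl, or a carboxylic acid on this aromatic carbon, would read in this assay.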